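The source may report more compounds than this note shows. Statements on the series, on what has been measured and on what is new or still open speak of the compounds shown alone.

Compound 1 `c1ccc(-c2ccncc2)c(OCC2=NCCN2)c1` in a functional assay for activation of Alpha-1A adrenergic receptor (Homo sapiens), read by calcium flux; a higher number here means that more compound is needed for the effect, a lower number that less compound is needed: < 100000 nM
Compound 2 `Cc1cccnc1-c1ccccc1OCC1=NCCN1` in this assay: < 100000 nM

The value given for compound 1 is a limit of the assay, not a number. The value for compound 2 is likewise a limit. Both measured compounds therefore sit at the limit of < 100000 nM in this assay, at which 2 of the 2 values shown sit, so compound 1 has no definite place among the numbers, only a position at that limit together with compound 2.

Compound 3 `c1ccc(-c2ccoc2)c(OCC2=NCCN2)c1` has not been measured yet. It differs from compound 1 by furan-3-yl in place of pyridin-4-yl on an aromatic carbon. Going by the values given here, no measured pair shows what such a change does in this assay, and since the starting point is itself only a limit, the expected step from compound 1 to compound 3 cannot be anchored to a number. The estimate for compound 3 is 10000 nM, with a range from 500 nM to 100000 nM, and the step it implies, a step that the limit leaves unreadable from compound 1 to compound 3, is an expectation only.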

Compound 3, half-maximal effective concentration: 0.501 nM
Estimate against measurement, compound 3: 20000-fold (4.30 log units) above; the measured number lies below the stated range.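

Going by these compounds alone, no step from compound 1 to compound 3 can be read, because compound 1 stands at a limit of the assay and not at a number: the limit of < 100000 nM in this assay, at which 2 of the 3 values shown sit. The compounds shown leave open how much furan-3-yl in place of pyridin-4-yl changes the value in this assay.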